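Cyclopropenone aryl series: trimming the benzyl ether

The compounds below may be only part of what the source reports. "The series", "measured", "known", "first", "only" and "open" are said of these compounds alone.

Going by the values given here, compound 3 `O=c1cc1-c1ccc(OCc2ccccc2)cc1` gives 730 nM in an assay on isolated protein for inhibition of glutathione S-transferase P (Homo sapiens) (on this read-out lower numbers stand for stronger inhibition and higher numbers for weaker inhibition), the second highest of the three numbers so far. Compound 1 `O=c1cc1-c1ccc2ccccc2c1` gives 360 nM, and compound 2 `O=c1cc1-c1ccc(OCc2ccc(-c3ccccc3)cc2)cc1` gives 3200 nM. Among the compounds with values here, the only step measured on the ether side is a 4.4-fold lower number from compound 2 to compound 3 (0.64 log units; beyond the scatter). Compound 4 `C#CCOc1ccc(-c2cc2=O)cc1` differs from compound 3 by ethynyl in place of phenyl on a saturated chain carbon bound to an oxygen on an aromatic ring. Within the data shown here, no measured step tests this exact change; the step from compound 2 to compound 3 shows that shortening the ether substituent is tolerated, but it removed a ring rather than replacing one with a chain. For compound 4 the expected number is 900 nM, with a range of 300 nM to 2700 nM. The step from compound 3 to compound 4 is therefore estimated at a 1.2-fold higher number from compound 3 to compound 4 (0.09 log units; within the scatter), not clearly beyond the scatter in either direction.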

Compound 4, half-maximal inhibitory concentration: 1640 nM
For compound 4 the middle estimate is 1.8-fold (0.26 log units) below the measured one; the range from low to high includes it.
By their numbers in this assay, from the lowest: compound 1; then compound 3; then compounds 4 and 2 (each within the scatter of the next).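

In this assay, ethynyl in place of phenyl on the saturated chain carbon gives a 2.2-fold higher number from compound 3 to compound 4 (0.35 log units; beyond the scatter), so this phenyl cannot be exchanged for the smaller group without a loss beyond the scatter. Removing atoms from the ether substituent therefore does not lower the number throughout: the earlier trimming gave a 4.4-fold lower number from compound 2 to compound 3 (0.64 log units; beyond the scatter), and compound 4 goes against that trend. Nothing available gives a reason for this step. Going by these compounds, whether the lost ring or the triple bond governs the step stays open; a cyclohexyl or an ethyl group at this carbon would separate the two.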